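This account rests on a few compounds, and the source may have more. Where it says the series, first, only, none or still open, it means among the compounds named here.

In a physicochemical assay for solubility (on this read-out lower numbers stand for lower solubility and higher numbers for higher solubility), compound 1 (`CNC(=O)c1cc(C(=O)N[C@H]2[C@@H]3COC[C@@H]32)cc2c1OC[C@H]2c1cccnc1`) gives >= 104 ug/mL as a limit of the assay and not as a number. Compound 2 (`CNC(=O)c1cc(C(=O)N[C@H]2[C@@H]3COC[C@@H]32)cc2c1OC[C@H]2c1ccccc1`) gives >= 165 ug/mL as a limit too. Compound 3 (`CNC(=O)c1cc(C(=O)N[C@H]2[C@@H]3COC[C@@H]32)cc2c1O[C@H](CF)[C@H]2c1ccccc1`) gives >= 206 ug/mL as a limit as well, so it has no exact value and stands, like the other two compounds, on a limit alone.

Compound 4 (`CNC(=O)c1cc(C(=O)N[C@@H]2C[C@H]2C)cc2c1O[C@H](CF)[C@H]2c1ccccc1`) keeps the rest of compound 3 and changes one group: a group of 4 heavy atoms (4 carbon; one three-membered non-aromatic ring of carbon only) in place of a group of 6 heavy atoms (5 carbon, 1 oxygen; one three-membered non-aromatic ring of carbon only, one five-membered non-aromatic ring with 1 hetero atom), on an amide-type nitrogen with 2-methylcyclopropyl as the entering group.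

The measured steps offer little guidance. There is a step that the two limits leave unreadable from compound 1 to compound 2 and there is a step that the two limits leave unreadable from compound 2 to compound 3 elsewhere in the molecule. Neither step changes the group on the amide-type nitrogen, and neither has a readable size, so no size can be carried over to the new change.

For compound 3 the limit of >= 206 ug/mL is therefore the only anchor for the expectation. A modest downward move is expected, though this is a cautious guess and a result within the usual scatter would be no surprise. The expected change is an at least 1.4-fold lower number from compound 3 to compound 4 (0.16 log units; that floor lies within the scatter) in this assay on this reasoning. Compound 4 is estimated at 140 ug/mL with an expected range from 50 ug/mL to 350 ug/mL in this wide estimate.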

Compound 4, solubility: 7 ug/mL
For compound 4 the middle estimate is 20-fold (1.30 log units) above the measured one; measured number below the stated range.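

In this assay, the group on the amide-type nitrogen proves to be a place where one change can move the read-out a long way: putting 2-methylcyclopropyl in place of the group with the three-membered and five-membered rings gives an at least 29-fold lower number from compound 3 to compound 4 (1.46 log units; beyond the scatter). This is the only step shown with a readable size, since the two earlier steps, both on saturated ring carbons, cannot be read, so it is also the first sign of how far a single change in this series can reach. Its size is a minimum and not an exact figure, because the value for compound 3 is a limit of the assay and not a number: the limit of >= 206 ug/mL in this assay, at which 1 of the 4 values shown sits.

The compounds shown cannot say which part of the change matters, whether the loss of the ring oxygen, the loss of the five-membered ring or the arrival of the methyl group, and they give no reason for the step. As far as these compounds go, it also remains open whether an amine or a carboxylic acid on a small ring at this amide-type nitrogen would give a value closer to that of compound 3 or to that of compound 4.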